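Trifluoromethyl for formyl on the shared core

This account rests on a few compounds, and the source may have more. Where it says the series, first, only, none or still open, it means among the compounds named here.

Of the compounds shown here, three on the shared core have been measured. Compound 1 `CCC(=O)c1ccc2c(c1)C(n1ccccc1=O)=CC(C)(C)O2` gives 6.63 in a functional assay (aorta) with Rattus norvegicus as the target; on this read-out lower numbers stand for lower potency and higher numbers for higher potency (the scale is a negative logarithm). Compound 2 `CC1(C)C=C(n2ccccc2=O)c2cc(C(=O)c3ccccc3F)ccc2O1` gives 7.08 in this assay. Compound 3 `CC1(C)C=C(n2ccccc2=O)c2cc(C=O)ccc2O1` gives 6.91 in this assay, the second highest of the three numbers; its nearest neighbour is compound 2, its furthest compound 1, and both gaps are within the scatter.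

Compound 4 `CC1(C)C=C(n2ccccc2=O)c2cc(C(F)(F)F)ccc2O1` is not yet measured. It differs from compound 3 in one place: trifluoromethyl in place of formyl on an aromatic carbon.

The three measured steps all change the group on a carbonyl carbon: a number 0.45 log units higher from compound 1 to compound 2 (beyond the scatter), a number 0.28 log units higher from compound 1 to compound 3 (within the scatter) and a number 0.17 log units lower from compound 2 to compound 3 (within the scatter). Only the first of these lies beyond the scatter, and even it is modest. Within the data shown here, none of them removes the carbonyl itself, as the step to compound 4 does, so no measured step bears on it directly. What the series shows is that changing the substituent at this position of the aromatic ring moves this assay little. The step to compound 4 is therefore expected to stay within the scatter, with no direction preferred, at a number 0.06 log units lower from compound 3 to compound 4 (within the scatter).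

Compound 4 is expected to give about 6.85 in this assay, within 6.3 to 7.4.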

Compound 4, logarithm of the reciprocal of the active concentration, log(1/C): 7.61
Beside the measured number, compound 4's estimate is 0.76 log units below it, and the stated range ends below it.
By their numbers in this assay, from the lowest: compounds 1, 3 and 2 (each within the scatter of the next, the first and the last beyond it); then compound 4.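

Changing the whole group on this aromatic carbon moves the number further than changing what sits on the carbonyl: in this assay the steps are a number 0.70 log units higher from compound 3 to compound 4 (beyond the scatter), a number 0.53 log units higher from compound 2 to compound 4 (beyond the scatter) and a number 0.98 log units higher from compound 1 to compound 4 (beyond the scatter), each larger than any step among the three carbonyl compounds. The position is therefore not as flat as those compounds suggested, and compound 4, the only one here without a carbonyl at this carbon, stands above all three, with none of the four going against that order. Nothing measured here speaks to what lies behind the gain.

With a single compound lacking the carbonyl, the series cannot separate the loss of the carbonyl from the presence of trifluoromethyl itself, since the two arrive together in every step to compound 4. A nitrile, a methyl group or a carboxylic acid on the same aromatic carbon would be needed to tell whether any non-carbonyl group gives this rise or whether it belongs to trifluoromethyl alone.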